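The source may report more compounds than this note shows. Statements on the series, on what has been measured and on what is new or still open speak of the compounds shown alone.

Three compounds have been measured in a functional assay on DU-145 cells (Homo sapiens) for inhibition, read by trypan blue exclusion, with a stated time of 96 h; a lower number here means a stronger inhibitor of growth, a higher number a weaker inhibitor of growth:

Compound 1, `Cc1ccc(S/C(=C/c2c[nH]c3ccc(Cl)cc23)C(=O)c2ccc(Br)cc2)cc1`: 1000 nM
Compound 2, `Cc1ccc(S/C(=C/c2c[nH]c3ccc(Br)cc23)C(=O)c2ccc(Br)cc2)cc1`: 1000 nM
Compound 3, `CSc1ccc(/C=C(/SCc2ccc(Br)cc2)C(=O)c2ccc(C(=O)O)cc2)cc1`: 10000 nM

Compound 4, `CSc1ccc(/C=C(/SCc2ccc(Cl)cc2)C(=O)c2ccc(C(=O)O)cc2)cc1`, has not yet been measured in this assay. It differs from compound 3 by chloro in place of bromo on an aromatic carbon. The same kind of change separates compound 2 from compound 1, where it reads (chloro in place of bromo on an aromatic carbon); there the aromatic carbon sits in a ring that is part of a fused or bridged system of two rings, meta to a fused ring and para to a fused ring, whereas in compound 3 the ring is of carbon only and the place is para to a large group. In this assay that earlier change gave no change at the digits printed from compound 2 to compound 1 (within the scatter). How the core of compound 2 differs from the core of compound 3 is not broken down here; compound 3 simply gives the highest number of the three, beyond the scatter from compound 1 and from compound 2. Given no change at the digits printed from compound 2 to compound 1 (within the scatter), the step expected here is no change at the digits printed from compound 3 to compound 4 (within the scatter). Compound 4 is therefore estimated at 10000 nM, between 4000 nM and 25000 nM.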

Compound 4, concentration for 50% growth inhibition: > 100000 nM
Compound 4 ended at the assay's limit (the forecaster's own chance of this, stated with the estimate: 15%); at least 10-fold (1.00 log units) between middle value and limit.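

The value of compound 4 in this assay is a limit of the assay and not a number, so chloro in place of bromo in the (4-bromobenzyl)sulfanyl group gives an at least 10-fold higher number from compound 3 to compound 4 (1.00 log units; beyond the scatter), and the true size of this step is unknown: the limit of > 100000 nM in this assay, at which 1 of the 4 values shown sits.

The same change therefore does not carry over unchanged from the core of compound 2 to the core of compound 3: the same change on two cores in this assay, no change at the digits printed (within the scatter) from compound 2 to compound 1 and an at least 10-fold higher number (1.00 log units; beyond the scatter) from compound 3 to compound 4, at least 10-fold (1.00 log units) apart, beyond the scatter of two such steps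

This rests on a single pair on each core, and it does not show which part of the two cores sets the steps apart, nor how a further core would respond.

The compounds shown leave open how fluoro or iodo in the same place would read on either core. They also leave open whether bromo and chloro would still part so sharply on the core of compound 3 with a methyl ester or an amide in place of the carboxylic acid.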